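The compounds below may be only part of what the source reports. "The series", "measured", "known", "first", "only" and "open" are said of these compounds alone.

Compound 1 `O=C(N/N=C/c1ccco1)c1cccc(S(=O)(=O)N2CCOCC2)c1` reaches only a limit of the assay in a functional assay on EC9706 cells (Homo sapiens) for antiproliferative activity, read by MTT assay, with a stated time of 72 h (on this read-out lower numbers stand for stronger inhibition and higher numbers for weaker inhibition), where it gives > 100000 nM (the limit of > 100000 nM in this assay, at which 1 of the 3 values shown sits). Compound 2 `O=C(N/N=C/c1ccccn1)c1cccc(S(=O)(=O)N2CCOCC2)c1` gives 44300 nM in this assay, and compound 3 `O=C(N/N=C/c1ccccc1O)c1cccc(S(=O)(=O)N2CCOCC2)c1` gives 19600 nM, the lowest of the two numbers shown. Among the compounds with values here, the steps so far are an at least 2.2-fold lower number from compound 1 to compound 2 (0.35 log units; beyond the scatter), an at least 5.1-fold lower number from compound 1 to compound 3 (0.70 log units; beyond the scatter) and a 2.3-fold lower number from compound 2 to compound 3 (0.35 log units; beyond the scatter), each swapping the whole ring carried by the imine carbon. Compound 4 `CCN(CC)c1ccc(/C=N/NC(=O)c2cccc(S(=O)(=O)N3CCOCC3)c2)c(O)c1` differs from compound 3 by diethylamino in place of hydrogen on an aromatic carbon. Within the data shown here, no measured step adds a group to a ring that is kept, so those steps guide only loosely; the change to compound 3 has brought the lowest number, and a further addition is expected to shift it modestly, as a 2.2-fold lower number from compound 3 to compound 4 (0.34 log units; beyond the scatter). Compound 4 is therefore estimated at 9000 nM, between 2500 nM and 35000 nM.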

Compound 4, half-maximal inhibitory concentration: 920 nM
For compound 4 the middle estimate is 9.8-fold (0.99 log units) above the measured one, and the stated range ends above it.
By their numbers in this assay, from the lowest: compound 4; then compound 3; then compound 2. At a limit, above all of these: compound 1.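

Until this point, only the whole ring on the imine carbon had changed. Here the 2-hydroxyphenyl ring is kept and diethylamino enters on an aromatic carbon, para to a large group, and in this assay this gives a 21-fold lower number from compound 3 to compound 4 (1.33 log units; beyond the scatter), a large step. So adding to the kept ring at this place can matter a great deal. On these data alone, whether dimethylamino, a methoxy group or a plain ethyl chain at the same place would do the same stays open. Nothing shown here explains the size of this step.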